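Swapping a sulfonyl arm for a fluorophenyl urea on compound 3

A few compounds are considered here, and "the series" means these few. Any claim that something is new, unique, unknown or untested is made for them only; others in the source may bear on it.

Of the compounds shown here, three sharing one core have been measured in a functional assay on MDA-MB-436 cells (Homo sapiens) for antiproliferative activity, read by MTT assay, with a stated time of 48 h; a lower number here means a stronger inhibitor, a higher number a weaker inhibitor. Compound 1 `C=CS(=O)(=O)N1CCN(c2ncnc3sc(-c4ccc(C#N)cc4)cc23)CC1` gives 9170 nM. Within the data shown here, compound 2 `C=CS(=O)(=O)N1CCN(c2ncnc3sc(-c4cccs4)cc23)CC1` gives 39000 nM, and the one change between them, a 4.3-fold higher number from compound 1 to compound 2 (0.63 log units; beyond the scatter), sits on an aromatic carbon of the core. Compound 3 `CN1CCN(c2ccc(-c3cc4c(N5CCN(S(=O)(=O)/C=C/c6ccccc6)CC5)ncnc4s3)cc2)CC1` gives 8670 nM, the lowest of the three numbers; its gap to compound 1 lies within the scatter, so the two cannot be ranked, while its gap to compound 2 lies beyond it.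

Compound 4 `CN1CCN(c2ccc(-c3cc4c(N5CCN(C(=O)Nc6cccc(F)c6)CC5)ncnc4s3)cc2)CC1` is the unmeasured compound. It differs from compound 3 in one place: (3-fluorophenyl)carbamoyl in place of (2-phenylethenyl)sulfonyl on an amine nitrogen in a ring. Among the measured compounds shown here, the only measured step concerns a different position, so no step in this set bears directly on this change, and the direction of its effect is open. For compound 4 a somewhat higher number in this assay is expected, with wide uncertainty: a 1.7-fold higher number from compound 3 to compound 4 (0.24 log units; within the scatter). The estimate for compound 4 is 15000 nM, within a range from 4000 nM to 60000 nM.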

Compound 4, half-maximal inhibitory concentration: 18300 nM
Estimate against measurement, compound 4: 1.2-fold (0.09 log units) below; the measured number falls inside the stated range.
By their numbers in this assay, from the lowest: compounds 3, 1 and 4 (each within the scatter of the next, the first and the last beyond it); then compound 2.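

Among these compounds, this is the first view of the amine nitrogen in the six-membered ring, a site the earlier step, made on an aromatic carbon of the core, could not address. In this assay, replacing (2-phenylethenyl)sulfonyl with (3-fluorophenyl)carbamoyl gives a modest but real loss (a 2.1-fold higher number from compound 3 to compound 4 (0.32 log units; beyond the scatter)), so the group at this nitrogen does affect the read-out, although this very different group, which brings a hydrogen-bond donor, does not abolish activity. Nothing available explains the rise in the number.

Among the compounds shown here, the single step changes the linking unit and the aromatic end together, so their separate contributions stay open. A plain phenylcarbamoyl group would test the fluorine alone, and a (3-fluorophenyl)acetyl group would test the nitrogen of the carbamoyl link.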